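A few compounds are considered here, and "the series" means these few. Any claim that something is new, unique, unknown or untested is made for them only; others in the source may bear on it.

Compound 1 `CCCCCCCn1c(N2CCN(C)CC2)nc2ccccc21` gives 150 nM in a functional assay on ileum for inhibition of histamine H1 receptor (Cavia porcellus); a lower number here means a stronger inhibitor, a higher number a weaker inhibitor. Among the compounds with values here, compound 2 `CCCSCn1c(N2CCN(C)CC2)nc2ccccc21` gives 68 nM in this assay, the lowest of the two numbers so far. Within the data shown here, the one measured step at this position, a 2.2-fold lower number from compound 1 to compound 2 (0.34 log units; beyond the scatter), is the only guide. Compound 3 `CC(C)CCn1c(N2CCN(C)CC2)nc2ccccc21` carries isobutyl in place of propylsulfanyl on a saturated chain carbon bound to an aromatic nitrogen. That step went from hexyl to propylsulfanyl and lowered the number; the change to compound 3 returns to a plain chain, a shorter one, so a modest rise in this assay is expected, about a 1.6-fold higher number from compound 2 to compound 3 (0.21 log units; within the scatter). Compound 3 is therefore estimated at 110 nM, with a range of 50 nM to 250 nM.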

Compound 3, half-maximal inhibitory concentration: 1400 nM
For compound 3 the middle estimate is 13-fold (1.10 log units) below the measured one; measured number outside the range, above it.
By their numbers in this assay, from the lowest: compound 2; then compound 1; then compound 3.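

In this assay this position proves far more sensitive than the first step suggested: isobutyl in place of propylsulfanyl gives a 21-fold higher number from compound 2 to compound 3 (1.31 log units; beyond the scatter). Loss of the sulfur cannot be the whole story, as the all-carbon pair also moves, with isopropyl in place of pentyl giving a 9.3-fold higher number from compound 1 to compound 3 (0.97 log units; beyond the scatter). No measurement at hand accounts for the size of these steps.

Compound 3 differs from compound 1 in both branching and chain length, and the two remain unseparated. On these data alone, an unbranched butyl chain or an ether oxygen in place of the sulfur remains open.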